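Thiophene to methyl-isothiazole on the imidazoline aryl ether core

The source may hold more compounds than are shown below. What is called first, only, known or untested is meant among the compounds shown, and "the series" means these compounds.

Compound 2 `c1ccc(-c2ccsc2)c(OCC2=NCCN2)c1` sits at the lowest number of the two measured: in a functional assay for activation of Alpha-1A adrenergic receptor (Homo sapiens), read by calcium flux (on this read-out lower numbers stand for an effect already at smaller amounts and higher numbers for an effect only at larger amounts of compound), compound 2 gives 0.251 nM, while compound 1 `c1cnc(-c2ccccc2OCC2=NCCN2)nc1` gives 1260 nM. Compound 3 `Cc1cc(-c2ccccc2OCC2=NCCN2)sn1` is not yet measured; the change is 3-methyl-1,2-thiazol-5-yl in place of thiophen-3-yl on an aromatic carbon. Going by the values given here, the one measured step bearing on this position, a 5000-fold lower number from compound 1 to compound 2 (3.70 log units; beyond the scatter), shows that swapping the aromatic group can move the number far, though that step went from a six-membered to a five-membered ring. Here both rings are five-membered, so a moderate step is expected, toward a higher number, a 12-fold higher number from compound 2 to compound 3 (1.08 log units; beyond the scatter). Compound 3 is estimated at 3 nM, between 0.4 nM and 25 nM.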

Compound 3, half-maximal effective concentration: 158 nM
For compound 3 the middle estimate is 53-fold (1.72 log units) below the measured one; the measured number lies above the stated range.
By their numbers in this assay, from the lowest: compound 2; then compound 3; then compound 1.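

Two five-membered aromatic rings are not interchangeable at this position: 3-methyl-1,2-thiazol-5-yl in place of thiophen-3-yl gives a 630-fold higher number from compound 2 to compound 3 (2.80 log units; beyond the scatter), so ring size alone does not set the number. The same group still keeps part of the gain over pyrimidin-2-yl, with an 8.0-fold lower number from compound 1 to compound 3 (0.90 log units; beyond the scatter), and among these three groups thiophen-3-yl gives the lowest number. No measurement available here accounts for either step.

As far as these compounds go, the ring nitrogen and the methyl enter together in compound 3, so their separate shares remain open. A 1,2-thiazol-5-yl without the methyl, or a methylthiophene, would separate them.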